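Chloro for Methyl on a Cinnamoyl Sulfonamide

A few compounds are considered here, and "the series" means these few. Any claim that something is new, unique, unknown or untested is made for them only; others in the source may bear on it.

Of the compounds shown here, three built on one shared core have been tested in a functional assay on B16-F10 cells (Mus musculus) for antiproliferative activity, read by ELISA and MTT assay, with a stated time of 48 h; a lower number here means a stronger inhibitor, a higher number a weaker inhibitor. Compound 1 `Cc1ccc(S(=O)(=O)NC(=O)/C=C/c2ccccc2)cc1` gives 13.8 ug/mL in this assay. Compound 2 `O=C(/C=C/c1ccccc1)NS(=O)(=O)c1ccc(Cl)cc1` gives 2.2 ug/mL, and compound 3 `Cc1ccc(S(=O)(=O)NC(=O)/C=C/c2ccc(Cl)cc2)cc1` gives 4.6 ug/mL. Among these three numbers compound 3 stands second highest: compound 2 sits lower and compound 1 sits higher, and both gaps are beyond the scatter.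

Compound 4 `O=C(/C=C/c1ccc(Cl)cc1)NS(=O)(=O)c1ccc(Cl)cc1` has not yet been measured. It differs from compound 3 in one place: chloro in place of methyl on an aromatic carbon

The same exchange has been seen once already, in the step of a 6.3-fold lower number from compound 1 to compound 2 (0.80 log units; beyond the scatter). A second, related step, a 3.0-fold lower number from compound 1 to compound 3 (0.48 log units; beyond the scatter), shows that adding a chloro on the other ring also lowered the number. Both steps point the same way, so a lower number is expected for compound 4 in this assay, and the step of a 5.1-fold lower number from compound 3 to compound 4 (0.71 log units; beyond the scatter) is estimated to be of a size comparable to the earlier exchange. Compound 4 is therefore estimated at 0.9 ug/mL, with a plausible range from 0.35 ug/mL to 2.5 ug/mL.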

Compound 4, half-maximal inhibitory concentration: 2.5 ug/mL
Compound 4: the middle estimate sits 2.8-fold (0.44 log units) below what was measured, within the range that was stated.
By their numbers in this assay, from the lowest: compounds 2, 4 and 3 (each within the scatter of the next, the first and the last beyond it); then compound 1.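

Methyl to chloro at this position does not have a fixed effect: with a chloro already on the other ring, the exchange gives only a 1.8-fold lower number from compound 3 to compound 4 (0.26 log units; within the scatter), and its two occurrences clearly disagree: the same change on two cores in this assay, a 6.3-fold lower number (0.80 log units; beyond the scatter) from compound 1 to compound 2 and a 1.8-fold lower number (0.26 log units; within the scatter) from compound 3 to compound 4, 3.4-fold (0.53 log units) apart, beyond the scatter of two such steps. A chloro on the other ring, which lowered the number on the core of compound 1, likewise shows no clear gain once the first chloro is present, with a 1.1-fold higher number from compound 2 to compound 4 (0.06 log units; within the scatter), and this also departs from the earlier step: the same change on two cores in this assay, a 3.0-fold lower number (0.48 log units; beyond the scatter) from compound 1 to compound 3 and a 1.1-fold higher number (0.06 log units; within the scatter) from compound 2 to compound 4, 3.4-fold (0.53 log units) apart, beyond the scatter of two such steps. In these four compounds, then, the two chloro gains do not add up, and the second chloro brings no change that stands clear of the scatter.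

From the compounds shown here alone, it remains open whether a fluoro, a methoxy or a nitrile at this place would move the number beyond the scatter on a core that already carries a chloro. Why the gain vanishes also cannot be told from the numbers in this assay.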